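The source may report more compounds than this note shows. Statements on the series, on what has been measured and on what is new or still open speak of the compounds shown alone.

Measured so far:
compound 1 `COc1cc(NC(=O)Nc2cccc(F)c2)cc(OC)c1OC` — 111000 nM
compound 2 `COc1cc(NC(=O)Nc2ccc(O)c3ccccc23)cc(OC)c1OC` — 100 nM

Among the compounds with values here, in a functional assay on Daoy cells (Homo sapiens) for cytotoxicity, read by MTT assay, with a stated time of 72 h (a lower number here means a stronger inhibitor, a higher number a weaker inhibitor), compound 1 gives 111000 nM, the highest of the two numbers, and the only other value, compound 2 at 100 nM, is a much lower one, beyond the scatter. Compound 3 `COc1ccc(NC(=O)Nc2cc(OC)c(OC)c(OC)c2)cc1` is compound 1 with a change on the same side of the urea: 4-methoxyphenyl in place of 3-fluorophenyl on an amide-type nitrogen. Within the data shown here, no measured pair shows what this change does. Since compound 1 stands at 111000 nM and the new group is a similarly small single ring, the step of a 1.2-fold lower number from compound 1 to compound 3 (0.09 log units; within the scatter) is expected to be none beyond the scatter. Compound 3 is estimated at 90000 nM, with a range from 25000 nM to 300000 nM.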

Compound 3, half-maximal inhibitory concentration: 14900 nM
Beside the measured number, compound 3's estimate is 6.0-fold (0.78 log units) above it, and the stated range ends above it.
By their numbers in this assay, from the lowest: compound 2; then compound 3; then compound 1.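

In this assay, 4-methoxyphenyl in place of 3-fluorophenyl on the amide-type nitrogen gives a 7.4-fold lower number from compound 1 to compound 3 (0.87 log units; beyond the scatter). This position therefore responds even when one six-membered aromatic ring of carbon only replaces another, so the number depends on the group the ring carries and not just on the ring being there. Nothing available here says why the number moves.

Going by these compounds, what a plain phenyl or an aminophenyl would give at this place remains open. The step therefore cannot yet be assigned to gaining the methoxy group or to losing the fluorine.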